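A few compounds are considered here, and "the series" means these few. Any claim that something is new, unique, unknown or untested is made for them only; others in the source may bear on it.

Series so far, in a functional assay on HCT-116 cells (Homo sapiens) for inhibition, read by MTT assay, with a stated time of 72 h; a lower number here means a stronger inhibitor of growth, a higher number a weaker inhibitor of growth:
- compound 1 `CNC(=O)CCc1ccncc1-c1ccc2ccccc2c1`: 19300 nM
- compound 2 `O=C(/C=C/c1ccncc1-c1ccc2ccccc2c1)N1CCOCC1`: 6040 nM

Compound 2 holds the lower of the two numbers, and its gap to compound 1 lies beyond the scatter. The two compounds differ in more than one place, so that gap cannot be tied to a single change.

Next is compound 3 `NC(=O)/C=C/c1ccncc1-c1ccc2ccccc2c1`, which differs from compound 2 by amino in place of morpholin-4-yl on a carbonyl carbon. Within the data shown here, no measured pair isolates this change, so the data offer only thin guidance. The one other reference point, compound 1 at 19300 nM, lies higher. A moderate rise in this assay is therefore expected, towards weaker growth inhibition, with an estimated step of a 2.2-fold higher number from compound 2 to compound 3 (0.33 log units; beyond the scatter). The estimate for compound 3 is 13000 nM, with an expected range of 4500 nM to 38000 nM.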

Compound 3, concentration for 50% growth inhibition: 12100 nM
Estimate against measurement, compound 3: 1.1-fold (0.03 log units) above, and the stated range covers the measured number.
By their numbers in this assay, from the lowest: compounds 2, 3 and 1 (each within the scatter of the next, the first and the last beyond it).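

In this assay amino in place of morpholin-4-yl on a carbonyl carbon gives a 2.0-fold higher number from compound 2 to compound 3 (0.30 log units; within the scatter) and so shows that the six-membered ring can be lost without a shift beyond the scatter. 2-Carbamoylethenyl in place of 2-(methylcarbamoyl)ethyl on an aromatic carbon gives a 1.6-fold lower number from compound 1 to compound 3 (0.20 log units; within the scatter) and so also leaves no readable shift. No measured property bears on either step, and neither can be explained from these data.

Going by these compounds, whether other groups on this carbonyl carbon, such as dimethylamino, piperazin-1-yl or a hydroxyl giving a carboxylic acid, would move the number beyond the scatter remains open. Also open, on these data alone, is how the ethenyl-for-ethyl exchange and the loss of the methyl on the carbamoyl group would each read alone, as compound 1 and compound 3 carry both together.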